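Nitro in Place of Hydrogen on the Shared Core

A few compounds are considered here, and "the series" means these few. Any claim that something is new, unique, unknown or untested is made for them only; others in the source may bear on it.

Compound 1 `CC1=CC[C@H](C(C)(C)NC(=S)N/N=C/c2ccccc2)CC1` gives 1300 nM in a functional assay on PC-3 cells (Homo sapiens) for inhibition, read by sulforhodamine B assay, with a stated time of 48 h; on this read-out higher numbers stand for weaker inhibition of growth and lower numbers for stronger inhibition of growth.
Compound 2 `CC1=CC[C@H](C(C)(C)NC(=S)N/N=C/c2ccc(N(C)C)cc2)CC1` reaches only a limit of this assay, < 40 nM.

Among the two values shown, compound 1 carries the only plain number; the value for compound 2 is a limit and not a number. Among the compounds with values here, the one measured step, an at least 32-fold lower number from compound 1 to compound 2 (1.51 log units; beyond the scatter), has its size bounded by the limit of < 40 nM in this assay, at which 1 of the 2 values shown sits. Compound 3 `CC1=CC[C@H](C(C)(C)NC(=S)N/N=C/c2ccccc2[N+](=O)[O-])CC1` has not yet been measured; it differs from compound 1 by nitro in place of hydrogen on an aromatic carbon. Within the data shown here, the measured step swaps in a different group at a different place on the same ring, so it gives no direct guide to the nitro change; only the shared core and the one number for compound 1 anchor the expectation. Compound 3 is therefore expected to show a 1.4-fold lower number from compound 1 to compound 3 (0.16 log units; within the scatter), a step not beyond the scatter, with wide uncertainty in both directions. The estimate for compound 3 in this assay is 900 nM, with a range from 150 nM to 4000 nM.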

Compound 3, concentration for 50% growth inhibition: 1700 nM
The estimate for compound 3 lay 1.9-fold (0.28 log units) below the measured number; low and high end bracket the measured number.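

In this assay, nitro in place of hydrogen on an aromatic carbon, ortho to a large group, yields a compound that cannot be told apart from its parent (a 1.3-fold higher number from compound 1 to compound 3 (0.12 log units; within the scatter)). Not every change on this aromatic ring therefore moves the number beyond the scatter, as the earlier dimethylamino step did (an at least 32-fold lower number from compound 1 to compound 2 (1.51 log units; beyond the scatter)). Nothing shown explains why the nitro compound stays so close to compound 1.

On these data alone, it remains open whether another group at this same place, such as an amine or a carboxylic acid, would stay within the scatter as nitro does. As far as these compounds go, it is also open whether nitro would give a step beyond the scatter at the place that carries dimethylamino in compound 2.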